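This account rests on a few compounds, and the source may have more. Where it says the series, first, only, none or still open, it means among the compounds named here.

Measured in an assay on isolated protein for inhibition of cytosolic endo-beta-N-acetylglucosaminidase (Homo sapiens), tested at 1000 uM; a lower number here means less inhibition, a higher number more inhibition at the concentration tested (going by the name of the read-out):
compound 1 `O=C(O)[C@@H]1NC[C@@H](O)[C@@H](O)[C@H]1O`: 26%
compound 2 `O=C(O)[C@@H]1NC[C@@H](O)[C@H](O)[C@@H]1O`: 0.8%
compound 3 `O=C(O)[C@@H]1NC[C@H](O)[C@@H](O)[C@@H]1O`: 5.4%

Compound 1 stands highest of the three. Its two diastereomers fall well beneath it: a number 25.2 percentage points lower from compound 1 to compound 2 (beyond the scatter) and a number 20.6 percentage points lower from compound 1 to compound 3 (beyond the scatter), each step resting only on a change of configuration at two ring stereocentres (the fact that compounds 1 and 2 differ only in the configuration as drawn, (the fact that compounds 1 and 3 differ only in the configuration as drawn)). Compounds 2 and 3 lie within the scatter of each other.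

Compound 4 `O=C(O)[C@H]1NC[C@@H](O)[C@H](O)[C@H]1O` is a further diastereomer of compound 1: the two compounds have the same atoms and bonds and differ only in configuration as drawn: 2 of 4 stereo elements differ; a stereocentre at a saturated ring carbon is drawn R in compound 1 and S in compound 4; a stereocentre at a saturated ring carbon is drawn R in compound 1 and S in compound 4. The two measured steps of the same kind both drop inhibition to near zero, so a comparable loss is expected here, a number 20 percentage points lower from compound 1 to compound 4 (beyond the scatter). Compound 4 is estimated at 6% in this assay, with a range from 0% to 18%.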

Compound 4, a percentage reported as inhibition, at one concentration (the size of the read-out at that concentration, not a potency): 6.3%
The estimate for compound 4 lay 0.3 percentage points below the measured number; the measured number falls inside the stated range.
By their numbers in this assay, from the lowest: compounds 2, 3 and 4 (each within the scatter of the next); then compound 1.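

A third pair of ring stereocentres, both drawn R in compound 1 and S in compound 4, also gives a clear loss: a number 19.7 percentage points lower from compound 1 to compound 4 (beyond the scatter). Every diastereomer shown therefore sits beneath compound 1 in this assay, whether the two centres change in the same sense or in opposite senses. The mirror-image pair shows no separation (a number 0.9 percentage points higher from compound 3 to compound 4 (within the scatter)), and the remaining comparison also stays within the scatter (a number 5.5 percentage points higher from compound 2 to compound 4 (within the scatter)).

On these data alone, it remains open whether the configuration of compound 1 would keep its inhibition with a hydroxymethyl group or a methyl ester in place of the carboxylic acid. As far as these compounds go, the effect of inverting a single stereocentre also remains open.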